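The compounds below may be only part of what the source reports. "The series", "measured", "known", "first", "only" and "open" are said of these compounds alone.

Of the compounds shown here, two have so far been measured in a functional assay on NCI-H460 cells (Homo sapiens) for antiproliferative activity, read by CCK-8 assay, with a stated time of 72 h, tested at 2 uM; on this read-out higher numbers stand for a stronger effect at the one concentration tested and lower numbers for a weaker effect. Compound 1, `CCCCn1cnc2c(Nc3cccc(Cl)c3)nc(NCOCc3ccc(/C=C/C(=O)Nc4ccccc4N)cc3)nc21`, gives in this assay 25.7%. Compound 2, `CCCCn1cnc2c(Nc3ccccc3)nc(NCOCc3ccc(C(=O)Nc4ccccc4N)cc3)nc21`, gives in this assay 27.7%. Within the data shown here, of the two numbers, the one for compound 2 is the higher, but its gap to compound 1 is within the usual scatter, so the two results cannot be told apart. Among the measured compounds shown here, compound 1 and compound 2 also differ from each other at more than one place, so no single structural step between them can be read off.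

Compound 3, `CCCCn1cnc2c(Nc3cccc(Cl)c3)nc(NCOCc3ccc(C(=O)Nc4ccccc4N)cc3)nc21`, has not yet been measured. It differs from compound 2 in one place only: chloro in place of hydrogen on an aromatic carbon. Compound 1 carries the same chlorine on its anilino ring, but differs from compound 2 elsewhere as well, so nothing measured shows what this chlorine alone does. For the measured compounds named here, since the two known numbers sit so close together, the step from compound 2 to compound 3 is expected to be none beyond the scatter, a number 0.7 percentage points lower from compound 2 to compound 3 (within the scatter). Compound 3 is thus estimated at 27%, with a range from 14% to 40%.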

Compound 3, a percentage reported as inhibition, at one concentration (the size of the read-out at that concentration, not a potency): 56.9%
The estimate for compound 3 lay 29.9 percentage points below the measured number; measured number above the stated range.
By their numbers in this assay, from the lowest: compounds 1 and 2 (each within the scatter of the next); then compound 3.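

In this assay, the change from phenyl to 3-chlorophenyl gives a number 29.2 percentage points higher from compound 2 to compound 3 (beyond the scatter) and so shows that this ring does not tolerate every change silently: one chlorine atom, meta to a large group, is enough to move the read-out beyond the scatter. The other end of the molecule counts as well, as (2-aminophenyl)carbamoyl in place of 2-((2-aminophenyl)carbamoyl)ethenyl, with the chlorine kept, gives a number 31.2 percentage points higher from compound 1 to compound 3 (beyond the scatter) in the same comparison. The chlorine therefore does not guarantee a high number by itself: compound 1 carries the same 3-chlorophenyl group, yet its result cannot be told apart from that of compound 2.

Going by these compounds, it remains open whether a fluoro, bromo, methyl or methoxy group in the same place would give a similar rise, and whether chloro elsewhere on the ring would do so too. The results show the size of these steps but not the reason for them, and no measurement here bears on that reason.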